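The source may hold more compounds than are shown below. What is called first, only, known or untested is meant among the compounds shown, and "the series" means these compounds.

Compound 1, with structure `CCCCCCCCc1ccc(NC(=O)[C@H](N)CO)cc1`, is the starting point. In an assay on isolated protein for inhibition of sphingosine kinase 1 (Homo sapiens), read by mobility shift assay (a higher number here means a weaker inhibitor, a lower number a stronger inhibitor), compound 1 gives 5000 nM. Compound 2, with structure `CCCCCCCCc1ccc(NC(=O)C(C)(N)CO)cc1`, carries a 1-amino-1-(hydroxymethyl)ethyl group in place of the 1-amino-2-hydroxyethyl group on the carbonyl carbon. For compound 2 this assay reports only a limit, > 10000 nM, and the limit of > 10000 nM in this assay, at which 1 of the 2 values shown sits, marks that one of the two recorded values sits there. The recorded change is therefore an at least 2.0-fold higher number from compound 1 to compound 2 (0.30 log units; that floor lies within the scatter), so only a floor is known for that step.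

Compound 3, with structure `CCCCCCCCc1ccc(NC(=O)C(N)C(C)(C)O)cc1`, differs from compound 2 in one place: 1-amino-2-hydroxy-2-methylpropyl in place of 1-amino-1-(hydroxymethyl)ethyl on a carbonyl carbon. Within the data shown here, no measured step covers this kind of exchange, and the one step recorded points toward weaker inhibition. Compound 3 is expected to give 12000 nM in this assay, within a range from 3000 nM to 40000 nM, meaning an estimated step that the limit leaves unreadable from compound 2 to compound 3.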

Compound 3, half-maximal inhibitory concentration: 2100 nM
The estimate for compound 3 lay 5.7-fold (0.76 log units) above the measured number, and the stated range ends above it.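

Among these compounds, the one earlier step at this position pointed toward weaker inhibition, but the 1-amino-2-hydroxy-2-methylpropyl group gives a 2.4-fold lower number from compound 1 to compound 3 (0.38 log units; beyond the scatter), the first step toward stronger inhibition in this assay. Set against compound 2, the same exchange gives an at least 4.7-fold lower number from compound 2 to compound 3 (0.67 log units; beyond the scatter), so a larger group on this carbonyl carbon does not by itself mean weaker inhibition, and how its carbons are arranged matters. The size of that second step remains a floor, because compound 2 has a limit rather than a number: the limit of > 10000 nM in this assay, at which 1 of the 3 values shown sits.

The compounds shown leave open whether the gain continues with a larger group, such as an ethyl in place of each methyl or a cyclopropyl ring carrying the hydroxyl. They also leave open whether the hydroxyl itself is needed, which a methoxy group or a second amine in its place would test.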